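The source may hold more compounds than are shown below. What is called first, only, known or untested is meant among the compounds shown, and "the series" means these compounds.

Of the compounds shown here, three of one shared core have already been tested for their ability to slow the growth of a human melanoma cell line. In a functional assay on WM 266-4 cells (Homo sapiens) for antiproliferative activity, read by MTT assay, with a stated time of 24 h (on this read-out higher numbers stand for weaker inhibition of growth and lower numbers for stronger inhibition of growth), compound 1 `Oc1ccccc1C1CC(c2ccc(Cl)c(Cl)c2)=NN1c1ccccc1` gives 1570 nM. In this assay compound 2 `CSc1ccc(C2CC(c3ccc4c(c3)OCCO4)=NN2c2ccccc2)cc1` gives 6870 nM. In this assay compound 3 `c1ccc(COc2cccc(C3CC(c4ccc5c(c4)OCCO5)=NN3c3ccccc3)c2)cc1` gives 870 nM.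

Compound 2 stands highest of the three numbers. Compound 1 and compound 3 both give lower numbers, and each gap lies beyond the usual scatter of repeated measurements, so among these three compound 2 is the weakest inhibitor of growth. None of these three compounds differs from another in only one place, so no single structural change has yet been tied to a single measured step.

Compound 4 `FC(F)(F)c1ccc(C2CC(c3ccc4c(c3)OCCO4)=NN2c2ccccc2)cc1` is the next compound to be measured. It differs from compound 2 in one place: trifluoromethyl in place of methylsulfanyl on an aromatic carbon. Within the data shown here, no measured pair shows this particular exchange, so nothing in the data anchors its effect. The expectation for compound 4 is therefore a step from compound 2 of a 1.4-fold lower number from compound 2 to compound 4 (0.14 log units; within the scatter), not clearly beyond the scatter in either direction. On that basis compound 4 is estimated to give about 5000 nM in this assay, with a likely range from 1500 nM to 15000 nM.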

Compound 4, concentration for 50% growth inhibition: > 100000 nM
Compound 4 ended at the assay's limit; the forecaster's own chance of this, stated with the estimate: 10%; middle value at least 20-fold (1.30 log units) away from the limit.
By their numbers in this assay, from the lowest: compounds 3 and 1 (each within the scatter of the next); then compound 2. At a limit, above all of these: compound 4.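

Among these compounds, this is the first single change that can be read, and it shows that the group on this aromatic carbon, para to a large group, strongly affects the result: going from 4-(methylsulfanyl)phenyl to 4-(trifluoromethyl)phenyl gives an at least 14-fold higher number from compound 2 to compound 4 (1.16 log units; beyond the scatter) in this assay. A higher number here means weaker inhibition of growth, so this one exchange, with the rest of the molecule unchanged, is enough to weaken the compound sharply. The value of compound 4 is a limit of the assay and not a number, so the true size of this step stays unknown: the limit of > 100000 nM in this assay, at which 1 of the 4 values shown sits.

With only these two groups compared at this position, the compounds shown cannot tell which feature of the exchange matters, and they give no reason for the step. As far as these compounds go, it also remains open whether a methoxy group, an amine or a carboxylic acid on the same carbon would give a number closer to that of compound 2 or would also reach the limit.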